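Trifluoromethyl on the phenyl of compound 1: an open question

The source may report more compounds than this note shows. Statements on the series, on what has been measured and on what is new or still open speak of the compounds shown alone.

Measured compounds:
compound 1, `O=c1oc2ccccc2n1CCN1CCN(c2ccccc2)CC1`: > 50 mg/kg
compound 2, `O=c1oc2cccnc2n1CN1CCN(c2ccccc2Cl)CC1`: 22.2 mg/kg

Of the compounds shown here, two have been tested in a functional assay on the whole organism with Mus musculus as the target; a higher number here means that more compound is needed for the effect, a lower number that less compound is needed. For compound 1 the value > 50 mg/kg is a limit of the assay, not a number; this is the case at the limit of > 50 mg/kg in this assay, at which 1 of the 2 values shown sits. Compound 2 gives 22.2 mg/kg in this assay. Compound 2 differs from compound 1 in several places at once, so its number says nothing direct about any single change.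

Compound 3, `O=c1oc2ccccc2n1CCN1CCN(c2cccc(C(F)(F)F)c2)CC1`, has not yet been measured in this assay. It differs from compound 1 by trifluoromethyl in place of hydrogen on an aromatic carbon. For the measured compounds named here, no measured pair shows this change on its own, so there is no step from which to read its size or direction. Since compound 1 sits only at a limit, compound 3 could land at the limit again or anywhere below it, and the account can only state an expectation.

Compound 3 is expected to give about 35 mg/kg in this assay, within 12 mg/kg to 100 mg/kg. The step from compound 1 to compound 3 is thus expected to be an at least 1.4-fold lower number from compound 1 to compound 3 (0.15 log units; that floor lies within the scatter), with a real chance that only a limit is reported again.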

Compound 3, dose for half-maximal effect: 30.2 mg/kg
The estimate for compound 3 lay 1.2-fold (0.06 log units) above the measured number, within the range that was stated.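

Trifluoromethyl in place of hydrogen on an aromatic carbon, meta to a large group, now has a step of its own in this assay, which the earlier compounds did not offer: an at least 1.6-fold lower number from compound 1 to compound 3 (0.21 log units; that floor lies within the scatter). That step can be read only as a floor, because the value of compound 1 is a limit of the assay and not a number: the limit of > 50 mg/kg in this assay, at which 1 of the 3 values shown sits. With trifluoromethyl at this place, compound 3 gives a measured dose on the core of compound 1, but since the floor lies within the scatter, the compounds do not establish that the change goes beyond it, and its true size may be larger.

The compounds shown leave open whether this result belongs to trifluoromethyl itself or would also appear with another group at the same place, such as a nitrile or a methoxy group. They also leave open how trifluoromethyl would fare elsewhere on the same six-membered ring, and whether the step would keep its direction and size on the core of compound 2.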